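The source may report more compounds than this note shows. Statements on the series, on what has been measured and on what is new or still open speak of the compounds shown alone.

Values in a functional assay (Homo sapiens) for inhibition (a higher number here means a weaker inhibitor, a lower number a stronger inhibitor), so far:

- compound 1 `CCCCCCc1cc(/C=C/C(=O)c2ccc(O)cc2)c(OC)cc1O` gives 46000 nM
- compound 2 `COc1cc(O)cc(C)c1/C=C/C(=O)c1ccc(O)cc1` gives 53000 nM
- compound 3 `COc1cc(/C=C/C(=O)c2ccccc2N(C)C)cc(OC)c1` gives 5700 nM

Compound 3 has the lowest number of the three, which makes it the strongest inhibitor here. The gaps from it up to compound 1 and to compound 2 both lie beyond the scatter of repeat measurements.

Compound 4 `COc1cc(/C=C/C(=O)c2ccccc2F)cc(OC)c1` has not been measured yet. It differs from compound 3 in one place: fluoro in place of dimethylamino on an aromatic carbon. In words, this is fluoro in place of dimethylamino on an aromatic carbon, ortho to a large group.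

For the measured compounds named here, no measured pair shows what this swap does, so any forecast is loose. Going by the values given here, the one guide is that compound 3, at 5700 nM, already sits at the low end of the numbers seen, so a rise looks likelier than a further fall. The expected change a 2.6-fold higher number from compound 3 to compound 4 (0.42 log units; beyond the scatter) is toward a weaker inhibitor, and it is only moderately beyond the scatter. Compound 4 is estimated at 15000 nM, with an expected range from 4000 nM to 55000 nM.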

Compound 4, half-maximal inhibitory concentration: 6000 nM
Compound 4: middle estimate off by 2.5-fold (0.40 log units), on the high side, within the range that was stated.
By their numbers in this assay, from the lowest: compounds 3 and 4 (each within the scatter of the next); then compounds 1 and 2 (each within the scatter of the next).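

In this assay, the step of a 1.1-fold higher number from compound 3 to compound 4 (0.02 log units; within the scatter) shows that dimethylamino and fluoro cannot be told apart on this aromatic carbon, ortho to a large group. Within this pair, the level of inhibition therefore does not depend on keeping the dimethylamino group, with its 3 heavy atoms and 1 hydrogen-bond acceptor: fluoro, with 1 heavy atom and 0 hydrogen-bond acceptors, gives a value within the scatter. No measurement here explains why the two groups match.

On these data alone, it remains open whether a chloro group, a nitrile or a primary amine on the same carbon would also fall within the scatter of these two compounds. Compound 1 and compound 2 each differ from compound 3 and compound 4 in more than one place, so no single group can be tied to the gaps between their values.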